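An Ethoxy Group Added Where Only Limits Have Been Seen

A few compounds are considered here, and "the series" means these few. Any claim that something is new, unique, unknown or untested is made for them only; others in the source may bear on it.

Compound 2 `COc1cc(-n2ncnc2-c2ccccc2)cc(OC)c1OC` is the reference point. In a functional assay on A549 cells (Homo sapiens) for antiproliferative activity, read by MTT assay, with a stated time of 72 h (on this read-out lower numbers stand for stronger inhibition and higher numbers for weaker inhibition), compound 2 gives > 10000 nM, which is a limit of the assay and not a measured number. Its two neighbours give no firmer footing. Compound 1 `COc1cc(-n2ncnc2-c2ccc(OC(C)C)cc2)cc(OC)c1OC` carries an isopropoxy group; in this assay compound 1 gives > 10000 nM, again a limit. Compound 3 `COc1cc(-n2ncnc2-c2cccc(Cl)c2)cc(OC)c1OC` carries a chloro group; in this assay compound 3 gives > 10000 nM, also a limit. The step that the two limits leave unreadable from compound 1 to compound 2 and the step that the two limits leave unreadable from compound 2 to compound 3 therefore cannot be sized, because of the limit of > 10000 nM in this assay, at which 3 of the 3 values shown sit.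

Compound 4 `CCOc1ccc(-c2ncnn2-c2cc(OC)c(OC)c(OC)c2)cc1` differs from compound 2 by ethoxy in place of hydrogen on an aromatic carbon, the change sitting para to a large group. Both measured steps bear on it, yet neither shows any movement into the readable range. Compound 1, with its isopropoxy group, gives > 10000 nM in this assay, a limit. The expected step that the limit leaves unreadable from compound 2 to compound 4 accordingly stays within the unreadable region. Compound 4 is estimated at 20000 nM, with a range from 8000 nM to 60000 nM, and most likely reported once more as a limit.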

Compound 4, half-maximal inhibitory concentration: 100 nM
The estimate for compound 4 lay 200-fold (2.30 log units) above the measured number; the measured number lies below the stated range.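

In this assay, for the compounds shown here, ethoxy in place of hydrogen on an aromatic carbon, para to a large group, gives a readable number for the first time, with an at least 100-fold lower number from compound 2 to compound 4 (2.00 log units; beyond the scatter). The same place is also sensitive to a single methyl on the oxygen-bound chain, since the isopropoxy of compound 1 and the ethoxy of compound 4 are separated by an at least 100-fold lower number from compound 1 to compound 4 (2.00 log units; beyond the scatter). The remaining steps among these compounds cannot be read, because their values sit at a limit: the limit of > 10000 nM in this assay, at which 3 of the 4 values shown sit.

The compounds shown leave open whether a methoxy group or a longer chain such as propoxy at this place would keep the number of compound 4. They also leave open whether the oxygen itself counts there, a question that an ethyl group or an amine at the same carbon would address.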